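A few compounds are considered here, and "the series" means these few. Any claim that something is new, unique, unknown or untested is made for them only; others in the source may bear on it.

Compound 1 `O=C1C(Nc2ccccc2F)=CC(=O)c2c1nc1n2[C@H]2OC[C@@H](O)[C@H]2OC1` is one of three compounds tested in a functional assay on MCF7 cells (Homo sapiens) for inhibition, read by sulforhodamine B assay; a lower number here means a stronger inhibitor, a higher number a weaker inhibitor. For compound 1 this assay gave only a limit, > 4000 nM, and not a number. Compound 2 `COc1ccc(NC2=CC(=O)c3nc4n(c3C2=O)[C@H]2OC[C@@H](O)[C@H]2OC4)cc1` carries a (4-methoxyphenyl)amino group and gives 5420 nM in this assay. Compound 3 `O=C1C=C(N2CCCCC2)C(=O)c2c1nc1n2[C@H]2OC[C@@H](O)[C@H]2OC1`, with piperidin-1-yl in place of that group, also reaches only a limit in this assay, > 8000 nM. Among the compounds with values here, the one step that can be sized, an at least 1.4-fold higher number from compound 2 to compound 3 (0.16 log units; that floor lies within the scatter), lies within the scatter, so the three compounds are all weak inhibitors with no clear ordering among them.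

Compound 4 `CCOc1ccccc1NC1=CC(=O)c2c(nc3n2[C@H]2OC[C@@H](O)[C@H]2OC3)C1=O` has not yet been measured. It arises from compound 1 by a single change: ethoxy in place of fluoro on an aromatic carbon. Within the data shown here, no measured pair shows this exchange, so the only guide is that every compound here sits at or near the limits. The nearest comparison, compound 2 with its (4-methoxyphenyl)amino group, stays weak at 5420 nM. Compound 4 is therefore expected to remain weak, with the step that the limit leaves unreadable from compound 1 to compound 4 expected to stay within the scatter. The estimate for compound 4 is 5000 nM, in a range from 1500 nM to 15000 nM, with a fair chance that the assay again reports only a limit.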

Compound 4, half-maximal inhibitory concentration: > 4000 nM
Compound 4 was reported as a limit; the forecaster's own chance of this, stated with the estimate: 50%; the middle value does not contradict the limit.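

The step from compound 1 to compound 4, ethoxy in place of fluoro, cannot be read, since both compounds stop at the same limit and give no number: the limit of > 4000 nM in this assay, at which 2 of the 4 values shown sit. The compounds shown leave open whether 2-ethoxyphenyl and 2-fluorophenyl differ at all in this assay.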